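Removing the aryl ketone arm from a triazole thioether

The source may report more compounds than this note shows. Statements on the series, on what has been measured and on what is new or still open speak of the compounds shown alone.

Measured compounds, each in a functional assay on A549 cells (Homo sapiens) for cytotoxicity, read by MTT assay, with a stated time of 48 h; on this read-out higher numbers stand for weaker inhibition and lower numbers for stronger inhibition:
- Compound 1, `Cc1nnc(SCc2ccccc2)n1N1C(=O)c2ccccc2C1=O`, gives > 200000 nM; this is a limit of the assay, not a number.
- Compound 2, `Cc1nnc(SCC(=O)c2ccc(Cl)cc2)n1N1C(=O)c2ccccc2C1=O`, gives > 200000 nM; this too is a limit.
- Compound 3, `Cc1ccc(C(=O)CSc2nnc(C)n2N2C(=O)c3ccccc3C2=O)cc1`, gives > 200000 nM; again a limit.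

Compound 2 therefore stands at the limit of the assay, and the two other values shown stand at the same limit (the limit of > 200000 nM in this assay, at which 3 of the 3 values shown sit). Compound 4, `CSc1nnc(C)n1N1C(=O)c2ccccc2C1=O`, is the next compound to be measured. It differs from compound 2 by a single change: hydrogen in place of (4-chlorophenyl)carbonyl on a saturated chain carbon bound to a sulfur. The measured steps that touch the same place are a step that the two limits leave unreadable from compound 1 to compound 2 and a step that the two limits leave unreadable from compound 1 to compound 3, and the step that the two limits leave unreadable from compound 2 to compound 3 changes the ring substituent on that arm. None of these steps can be read as to size or direction, so they give no measure of how much the group on the sulfur-bound carbon matters. Compound 4 is thus expected to remain at or near the limit, with a step that the limit leaves unreadable from compound 2 to compound 4 that is not readable against the scatter. The estimate for compound 4 is 250000 nM, within a range from 80000 nM to 800000 nM.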

Compound 4, half-maximal inhibitory concentration: > 200000 nM
Compound 4: no number, only a limit; the forecaster's own chance of this, stated with the estimate: 85%; the middle value is on the limit's open side.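

Compound 4 also gives only a limit, not a number, so no step linking it to compound 1, compound 2 or compound 3 can be read, because every value shown sits at the same limit: the limit of > 200000 nM in this assay, at which 4 of the 4 values shown sit. What the compounds shown leave open is whether any change to this series gives a measurable value in this assay.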